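Swapping a branched chain for a small ring on the amide nitrogen

This account rests on a few compounds, and the source may have more. Where it says the series, first, only, none or still open, it means among the compounds named here.

This study looks at two measured compounds and one still to be tested in a functional assay on BT-474 cells (Homo sapiens) for inhibition; a lower number here means a stronger inhibitor, a higher number a weaker inhibitor. Compound 1, with the structure `COc1c(C)cnc(CN2CC(=O)N(CCCC(C)C)c3c(Cl)nc(N)nc32)c1C`, gives 1650 nM and stands at the higher end of the two numbers recorded so far. Compound 2, with the structure `COc1c(C)cnc(CN2c3nc(N)nc(Cl)c3NC(=O)[C@@H]2C(C)C)c1C`, gives 760 nM, a lower number that sits beyond the usual scatter. Compound 3, with the structure `COc1c(C)cnc(CN2CC(=O)N(C3CCCC3)c3c(Cl)nc(N)nc32)c1C`, has not yet been measured. It differs from compound 1 in one place: cyclopentyl in place of 4-methylpentyl on an amide-type nitrogen in a ring. No comparable change between measured compounds is available, so there is nothing in these data that points firmly one way. The expectation is a step from compound 1 to compound 3 of about a 1.4-fold lower number from compound 1 to compound 3 (0.14 log units; within the scatter), small enough to fall close to the scatter. Compound 3 is therefore estimated at 1200 nM, within a range from 400 nM to 3600 nM.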

Compound 3, half-maximal inhibitory concentration: 290 nM
For compound 3 the middle estimate is 4.1-fold (0.62 log units) above the measured one; the measured number lies below the stated range.
By their numbers in this assay, from the lowest: compound 3; then compound 2; then compound 1.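

Among these compounds, this position on the amide-type nitrogen responds clearly to the group it carries: in this assay, cyclopentyl in place of 4-methylpentyl gives a 5.7-fold lower number from compound 1 to compound 3 (0.76 log units; beyond the scatter), the first single-change step in this set. The open chain is therefore not needed at this place, and a five-membered carbon ring with one heavy atom fewer gives the stronger inhibitor of this pair. Nothing measured here explains why the ring outperforms the chain.

Closing a ring and shortening the group happen together in this one step, so their separate contributions cannot be told apart. On these data alone, it also remains open how a straight pentyl chain, a cyclobutyl or cyclohexyl ring, or a cyclopentyl ring bearing an amine would compare at this nitrogen.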